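The source may hold more compounds than are shown below. What is called first, only, known or untested is meant among the compounds shown, and "the series" means these compounds.

Measured so far in one cytotoxicity read-out:

- compound 1, `COc1cc(-c2cc(/C=C/C(=O)c3ccc(N)cc3)[nH]n2)cc(OC)c1OC`, gives 83%
- compound 2, `COc1ccc(C(=O)/C=C/c2cc(-c3cc(OC)c(OC)c(OC)c3)n[nH]2)cc1OC`, gives 73%
- compound 3, `COc1ccc(-c2cc(/C=C/C(=O)c3ccc(N)cc3)[nH]n2)cc1OC`, gives 96%

All three numbers come from a functional assay on LOX IMVI cells (Homo sapiens) for cytotoxicity, read by sulforhodamine B assay, with a stated time of 48 h, tested at 1 uM; on this read-out lower numbers stand for a stronger effect and higher numbers for a weaker effect at the one concentration tested. Compound 3 and compound 1 differ in a single place, (methoxy in place of hydrogen on an aromatic carbon), and that change produced a number 13 percentage points lower from compound 3 to compound 1 (beyond the scatter). Compound 1 and compound 2 differ at the carbonyl carbon, and that step, a number 10 percentage points lower from compound 1 to compound 2 (within the scatter), stays within the scatter, so the two values are taken as alike. The difference between the core of compound 2 and the core of compound 3 is not broken down here.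

Compound 4, `COc1cc(C(=O)/C=C/c2cc(-c3cc(OC)c(OC)c(OC)c3)n[nH]2)cc(OC)c1OC`, has not yet been measured in this assay. It differs from compound 2 by methoxy in place of hydrogen on an aromatic carbon. The surroundings of the changed place are described in the same words as for the change from compound 3 to compound 1, so it is the same change made on a different core. The expected step is a number 13 percentage points lower from compound 2 to compound 4 (beyond the scatter), resting on the step of a number 13 percentage points lower from compound 3 to compound 1 (beyond the scatter) seen once already. For compound 4 the estimated value is 60%, expected to fall between 45% and 76%.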

Compound 4, a percentage reported as activity, at one concentration (the size of the read-out at that concentration, not a potency): 82%
Beside the measured number, compound 4's estimate is 22 percentage points below it; measured number above the stated range.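

In this assay, putting methoxy in place of hydrogen on the core of compound 2 gives a number 9 percentage points higher from compound 2 to compound 4 (within the scatter), so the clear drop seen on the other core does not reappear here. Set side by side, the two results for this one change do not agree: the same change on two cores in this assay, a number 13 percentage points lower (beyond the scatter) from compound 3 to compound 1 and a number 9 percentage points higher (within the scatter) from compound 2 to compound 4, 22 percentage points apart, beyond the scatter of two such steps. For the compounds shown here, this shows that, in this series, the result of this change on one core cannot simply be carried over to another, but it does not show which difference between the cores matters, and each core offers only a single pair.

Going by these compounds, whether a hydroxyl group or an ethoxy group in place of the methoxy would behave alike on both cores remains open. So does the question of whether the same disagreement would appear at other concentrations, since each value here is a reading at a single concentration and not a potency.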